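Oxazole amide series: swapping dimethylcarbamoyl for methylcarbamoyl

This account rests on a few compounds, and the source may have more. Where it says the series, first, only, none or still open, it means among the compounds named here.

Compound 3 `CN(C)C(=O)c1coc(C(=O)CCCCCCc2ccccc2)n1` stands at the weak end of the three measured analogues of this series: in an assay on HEK-293T cells for inhibition of diacylglycerol lipase-alpha (Homo sapiens), read by colorimetric assay (on this read-out lower numbers stand for stronger inhibition and higher numbers for weaker inhibition), compound 3 gives 3390 nM, while compound 1 `CC(=O)c1coc(C(=O)CCCCCCc2ccccc2)n1` gives 123 nM and compound 2 `O=Cc1coc(C(=O)CCCCCCc2ccccc2)n1` gives 1510 nM. The steps of a 28-fold higher number from compound 1 to compound 3 (1.44 log units; beyond the scatter) and a 2.2-fold higher number from compound 2 to compound 3 (0.35 log units; beyond the scatter) both run uphill towards compound 3. Compound 4 `CNC(=O)c1coc(C(=O)CCCCCCc2ccccc2)n1` differs from compound 3 by hydrogen in place of methyl on an amide-type nitrogen. Among the compounds with values here, no measured step touches the amide-type nitrogen itself; the recorded steps all concern the group on the carbonyl carbon, so they bear only loosely here. The expectation is therefore a step of a 1.2-fold lower number from compound 3 to compound 4 (0.08 log units; within the scatter) of no clear direction beyond the scatter. Compound 4 is estimated at 2800 nM in this assay, with a range of 900 nM to 9000 nM.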

Compound 4, half-maximal inhibitory concentration: > 10000 nM
Compound 4 gave a limit, no number (the forecaster's own chance of this, stated with the estimate: 5%); middle value at least 3.5-fold (0.55 log units) from the limit.
By their numbers in this assay, from the lowest: compound 1; then compound 2; then compound 3. At a limit, above all of these: compound 4.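

In this assay compound 4 stands as a limit, not a number: the limit of > 10000 nM in this assay, at which 1 of the 4 values shown sits. Hydrogen in place of methyl on the amide-type nitrogen is therefore not a neutral change at this position, giving an at least 2.9-fold higher number from compound 3 to compound 4 (0.46 log units; beyond the scatter). Methylamino on the carbonyl carbon also falls well behind the hydrogen and methyl groups there, with an at least 6.6-fold higher number from compound 2 to compound 4 (0.82 log units; beyond the scatter) and an at least 81-fold higher number from compound 1 to compound 4 (1.91 log units; beyond the scatter).

Going by these compounds, how far compound 4 lies past its limit stays open, so these steps have no upper size. Also open, on these data alone, is how an unsubstituted amino group on the carbonyl carbon, or an ethyl group on the amide-type nitrogen, would read.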